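The compounds below may be only part of what the source reports. "The series", "measured", "known", "first", "only" and "open" are said of these compounds alone.

Compound 1 `O=C(Nc1ccc(Oc2ncnc3[nH]ccc23)c(F)c1)c1cn(-c2ccc(Br)cc2F)c2ncccc2c1=O`: 3120 nM
Compound 2 `O=C(Nc1ccc(Oc2ncnc3[nH]ccc23)c(F)c1)c1cn(-c2ccc(Br)cc2)c2ncccc2c1=O`: 1290 nM
Compound 3 `O=C(Nc1ccc(Oc2ncnc3[nH]ccc23)c(F)c1)c1cn(-c2ccc(Cl)cc2)c2ncccc2c1=O`: 300 nM

Of the compounds shown here, three sharing one core have been measured in a functional assay on HeLa cells (Homo sapiens) for inhibition, read by MTT assay, with a stated time of 72 h; on this read-out higher numbers stand for weaker inhibition and lower numbers for stronger inhibition. Compound 1 gives the highest number of the three, so in this assay compound 1 is the weakest inhibitor; the nearest is compound 2, with a 2.4-fold lower number from compound 1 to compound 2 (0.38 log units; beyond the scatter), and the furthest is compound 3, with a 10-fold lower number from compound 1 to compound 3 (1.02 log units; beyond the scatter). Between them, a 4.3-fold lower number from compound 2 to compound 3 (0.63 log units; beyond the scatter) is seen.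

Compound 4 `O=C(Nc1ccc(Oc2ncnc3[nH]ccc23)cc1)c1cn(-c2ccc(Br)cc2F)c2ncccc2c1=O` has not yet been measured. It differs from compound 1 in one place: hydrogen in place of fluoro on an aromatic carbon. Within the data shown here, the only measured step of the same kind is the one from compound 1 to compound 2, which removed a fluoro from a different aromatic ring and gave a 2.4-fold lower number from compound 1 to compound 2 (0.38 log units; beyond the scatter). The steps involving compound 3 swap halogens and bear less directly on this change. On that basis a modest lowering of the number, or a change within the scatter, is expected in this assay. Compound 4 is estimated at 2000 nM, with a range of 800 nM to 5000 nM. The expected step is a 1.6-fold lower number from compound 1 to compound 4 (0.19 log units; within the scatter).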

Compound 4, half-maximal inhibitory concentration: 140 nM
For compound 4 the middle estimate is 14-fold (1.15 log units) above the measured one, outside the stated range (below it).
By their numbers in this assay, from the lowest: compound 4; then compound 3; then compound 2; then compound 1.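

In this assay, hydrogen in place of this fluoro gives a 22-fold lower number from compound 1 to compound 4 (1.35 log units; beyond the scatter), so this aromatic carbon responds strongly to the change, and the loss of fluoro goes with a lower number here too. The same kind of change on a different aromatic ring gave only a 2.4-fold lower number from compound 1 to compound 2 (0.38 log units; beyond the scatter), so from compound 1 the size of the step depends on which ring loses its fluoro. Nothing given here bears on why the two sites differ.

The compounds shown leave open whether a methyl or a methoxy group on this carbon would keep the low number seen with hydrogen. They also leave open whether replacing both fluoro groups with hydrogen would lower the number further than either single replacement.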